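Four-carbon chain variants on a trimethoxybenzyl core

The source may hold more compounds than are shown below. What is called first, only, known or untested is meant among the compounds shown, and "the series" means these compounds.

Three compounds sharing one core carry different groups on the saturated chain carbon bound to an aromatic nitrogen. Compound 1 `CCCCCn1c(Cc2cc(OC)c(OC)c(OC)c2)nc2c(N)nc(F)nc21` gives 286000000 nM in a functional assay on MCF7 cells (Homo sapiens) for cytotoxicity (a higher number here means that more compound is needed for the effect, a lower number that less compound is needed), compound 2 `COCCCn1c(Cc2cc(OC)c(OC)c(OC)c2)nc2c(N)nc(F)nc21` gives 72600000 nM, and compound 3 `CC[C@H](C)Cn1c(Cc2cc(OC)c(OC)c(OC)c2)nc2c(N)nc(F)nc21` gives 66700000 nM, the lowest of the three. Compound 4 `C=CCCCn1c(Cc2cc(OC)c(OC)c(OC)c2)nc2c(N)nc(F)nc21` differs from compound 3 by but-3-en-1-yl in place of sec-butyl on a saturated chain carbon bound to an aromatic nitrogen. The step that bears most on this is a 4.3-fold lower number from compound 1 to compound 3 (0.63 log units; beyond the scatter), where the group changed from butyl to sec-butyl; the step of a 1.1-fold lower number from compound 2 to compound 3 (0.04 log units; within the scatter) was small. For the measured compounds named here, no measured step involves a double bond, so compound 4 is expected to land close to compound 3, perhaps drifting toward compound 1, as a step of a 1.6-fold higher number from compound 3 to compound 4 (0.22 log units; within the scatter). Compound 4 is therefore estimated at 110000000 nM, with a range from 40000000 nM to 300000000 nM.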

Compound 4, half-maximal effective concentration: 55600000 nM
The estimate for compound 4 lay 2.0-fold (0.30 log units) above the measured number; the range from low to high includes it.
By their numbers in this assay, from the lowest: compounds 4, 3 and 2 (each within the scatter of the next); then compound 1.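

The but-3-en-1-yl chain brings the first double bond at this position, yet its number does not separate from the sec-butyl chain (a 1.2-fold lower number from compound 3 to compound 4 (0.08 log units; within the scatter)) or the 3-methoxypropyl chain (a 1.3-fold lower number from compound 2 to compound 4 (0.12 log units; within the scatter)). Against the butyl chain, the step lies beyond the scatter (a 5.1-fold lower number from compound 1 to compound 4 (0.71 log units; beyond the scatter)), so among these four compounds only compound 1 stands apart. No measured evidence accounts for this difference. Still open, on these data alone, is how an amine, a carboxylic acid or a longer chain at this position would compare.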